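Swapping the Sulfonyl Aryl: What Compound 4 Might Clear

The source may hold more compounds than are shown below. What is called first, only, known or untested is meant among the compounds shown, and "the series" means these compounds.

Compound 1 `COc1ccc(-c2c(S(=O)(=O)c3ccc(OC)cc3)cnc3cc(F)ccc23)cc1` gives 1.18 mL/min in an ADME assay on microsomes from liver (Homo sapiens) for metabolic stability, tested at 2.5 uM; on this read-out higher numbers stand for fast clearance and lower numbers for slow clearance.
Compound 2 `COc1ccc(S(=O)(=O)c2cnc3cc(F)ccc3c2-c2cccc(F)c2)cc1` gives 2.94 mL/min in this assay.
Compound 3 `COc1ccc(S(=O)(=O)c2cnc3cc(F)ccc3c2-c2ccc(F)cc2)cc1` gives 1.71 mL/min in this assay.

Among the three measured compounds, compound 1 has the lowest number in this assay; compound 3 sits nearest to it, and compound 2 is furthest, the only one separated from it beyond the scatter. Compound 4 `COc1ccc(-c2c(S(=O)(=O)c3ccc(F)c(Cl)c3)cnc3cc(F)ccc23)cc1` has not yet been measured. The change from compound 1 is 3-chloro-4-fluorophenyl in place of 4-methoxyphenyl on a sulfonyl sulfur.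

Among the measured compounds shown here, no measured step touches the group on the sulfonyl sulfur; the known steps alter the aryl on the aromatic carbon of the shared core. There, a 1.4-fold higher number from compound 1 to compound 3 (0.16 log units; within the scatter), and a 2.5-fold higher number from compound 1 to compound 2 (0.40 log units; beyond the scatter), while a 1.7-fold lower number from compound 2 to compound 3 (0.24 log units; within the scatter). Those steps suggest that trading a methoxy-bearing aryl for a halogenated one tends to move the number upward in this assay, modestly at most, with the larger move seen for compound 2.

By analogy, a small rise is expected for compound 4, so that a 1.6-fold higher number from compound 1 to compound 4 (0.21 log units; within the scatter). Compound 4 is therefore estimated at 1.9 mL/min, with a range from 0.9 mL/min to 3.8 mL/min.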

Compound 4, intrinsic clearance in a liver preparation (reported as CLH), per the amount of preparation that the assay uses: 1.08 mL/min
Compound 4: middle estimate off by 1.8-fold (0.25 log units), on the high side, and the stated range covers the measured number.
By their numbers in this assay, from the lowest: compounds 4, 1, 3 and 2 (each within the scatter of the next, the first and the last beyond it).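

In this assay, 3-chloro-4-fluorophenyl in place of 4-methoxyphenyl on the sulfonyl sulfur gives a 1.1-fold lower number from compound 1 to compound 4 (0.04 log units; within the scatter) and so cannot be told apart from no change. Among the compounds shown here, this is the only reading at this position, and it shows that a halogenated aryl can replace the methoxy-bearing one here while the number stays within the scatter. On the aromatic carbon of the shared core, such a trade gave mixed results: a 2.5-fold higher number from compound 1 to compound 2 (0.40 log units; beyond the scatter) but a 1.4-fold higher number from compound 1 to compound 3 (0.16 log units; within the scatter). Nothing available explains why the sulfonyl step stayed so small.

From the compounds shown here alone, whether a piperidine or an aryl carrying a carboxylic acid on the sulfonyl sulfur would move the number beyond the scatter remains open. So does whether the 3-chloro-4-fluorophenyl would behave the same alongside the fluorinated aryls of compound 2 or compound 3.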